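Removing one methoxy from a dimethoxy aryl sulfonate

A few compounds are considered here, and "the series" means these few. Any claim that something is new, unique, unknown or untested is made for them only; others in the source may bear on it.

Compound 1 `Cc1ccccc1OS(=O)(=O)c1ccc(N2CCN(C)C2=O)cc1` gives 2900 nM
Compound 2 `COc1ccc(OS(=O)(=O)c2ccc(N3CCN(C)C3=O)cc2)cc1OC` gives 8500 nM

In a functional assay on M21 cells (Homo sapiens) for antiproliferative activity, read by sulforhodamine B assay, with a stated time of 48 h (a higher number here means a weaker inhibitor, a lower number a stronger inhibitor), compound 2 gives 8500 nM, the higher of the two numbers, while compound 1 gives 2900 nM, and this gap lies beyond the usual scatter. The two differ in more than one place, so no single structural change can be read from them. Compound 3 `COc1ccc(OS(=O)(=O)c2ccc(N3CCN(C)C3=O)cc2)cc1` comes from compound 2 through one change, hydrogen in place of methoxy on an aromatic carbon, ortho to a methoxy group (hydrogen in place of methoxy on an aromatic carbon). For the measured compounds named here, no measured pair shows this change on its own. Going by the values given here, a small step toward a lower number is expected, no larger than the scatter, and the only lower number to guide it is compound 1 at 2900 nM. The estimated move is a 1.9-fold lower number from compound 2 to compound 3 (0.28 log units; within the scatter) in this assay. For compound 3 the expected value is 4500 nM, with an estimated range from 1500 nM to 13000 nM.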

Compound 3, half-maximal inhibitory concentration: > 100000 nM
Compound 3 was reported as a limit; the forecaster's own chance of this, stated with the estimate: 3%; at least 22-fold (1.34 log units) between middle value and limit.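

In this assay, the methoxy group on this aromatic carbon, ortho to a methoxy group, proves far from dispensable: replacing it with hydrogen gives an at least 11-fold higher number from compound 2 to compound 3 (1.07 log units; beyond the scatter), a large loss from a change of only 2 heavy atoms. The change of 4-methoxyphenyl in place of 2-methylphenyl on an oxygen gives an at least 34-fold higher number from compound 1 to compound 3 (1.53 log units; beyond the scatter), so a single methoxy group in that ring does not match the 2-methylphenyl group of compound 1 here. The reading for compound 3 is a limit and not a number: the limit of > 100000 nM in this assay, at which 1 of the 3 values shown sits.

From the compounds shown here alone, with a limit at one end, the full size of both steps stays open. Also open, going by these compounds, is whether a hydroxy group, an ethoxy group or a fluorine atom on this carbon would keep the level of compound 2.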